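A few compounds are considered here, and "the series" means these few. Any claim that something is new, unique, unknown or untested is made for them only; others in the source may bear on it.

Going by the values given here, compound 1 `NC1=NC2(CCSCC2)N(OCCCOc2cccc(Cl)c2)C(N)=N1` is the only member of this set with a reported result: in a functional assay on HepG2 cells (Homo sapiens) for antiproliferative activity, read by MTT assay, with a stated time of 72 h (on this read-out higher numbers stand for weaker inhibition and lower numbers for stronger inhibition), compound 1 gives 90 nM. Compound 2 `NC1=NC2(CCOCC2)N(OCCCOc2cc(Cl)c(Cl)cc2Cl)C(N)=N1` belongs to the same series, and in this assay compound 2 gives "not determined" (no result reported). Compound 3 `NC1=NC2(CCOCC2)N(OCCCOc2ccc(Br)cc2)C(N)=N1` likewise belongs to the same series, and in this assay compound 3 gives "not determined" (no result reported), so compound 1 stands alone on the numbers shown. Compound 4 `NC1=NC2(CCSCC2)N(OCCCOc2cccc(Br)c2)C(N)=N1` has not yet been measured. It differs from compound 1 by bromo in place of chloro on an aromatic carbon. Among the compounds with values here, no step between measured compounds is available to calibrate this change; a step of this kind is expected to stay within the usual scatter, in no fixed direction. Compound 4 is thus expected to give 80 nM in this assay, with a range from 35 nM to 200 nM. The expected step of a 1.1-fold lower number from compound 1 to compound 4 (0.05 log units; within the scatter) is estimated to lie within the scatter.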

Compound 4, half-maximal inhibitory concentration: 90 nM
For compound 4 the middle estimate is 1.1-fold (0.05 log units) below the measured one, and the stated range covers the measured number.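

Bromo in place of chloro on this aromatic carbon, meta to a large group, gives the first readable step in the set: in this assay it shows no change at the digits printed from compound 1 to compound 4 (within the scatter). At this position, then, the two halogens cannot be told apart on this read-out, and steps involving compound 2 or compound 3 cannot be read. No measured evidence bears on this result.

The compounds shown leave open how an amine, a methoxy group or a carboxylic acid would read at this position. They also leave open whether an unsubstituted phenoxy group would read the same.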